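From 4-methylphenyl to 3-(trifluoromethyl)phenyl: notes on compound 3

The compounds below may be only part of what the source reports. "The series", "measured", "known", "first", "only" and "open" are said of these compounds alone.

Among the compounds with values here, in a functional assay on MCF7 cells (Homo sapiens) for antiproliferative activity, read by MTT assay, with a stated time of 48 h (a lower number here means a stronger inhibitor, a higher number a weaker inhibitor), compound 2 (`COc1ccc(-c2c(Nc3ccc(C)cc3)c3ccc(O)cc3oc2=O)cc1`) stands at 85500 nM as the higher of the two numbers so far. Compound 1 (`COc1ccc(-c2c(Nc3cccc(C(F)(F)F)c3)c3ccc(OC)cc3oc2=O)cc1`) gives 36200 nM on the lower side, and the gap between the two lies beyond the scatter. Compound 3 (`COc1ccc(-c2c(Nc3cccc(C(F)(F)F)c3)c3ccc(O)cc3oc2=O)cc1`) has 3-(trifluoromethyl)phenyl in place of 4-methylphenyl on a nitrogen on an aromatic ring and is otherwise identical to compound 2. Within the data shown here, no measured pair isolates this change. Compound 3 differs elsewhere from compound 1, which carries the same 3-(trifluoromethyl)phenyl and gives 36200 nM as its number, so that value offers only weak guidance. In this assay a small step to a lower number is expected, within or near the scatter, estimated as a 1.6-fold lower number from compound 2 to compound 3 (0.19 log units; within the scatter) for this change. For compound 3 the expected value is 55000 nM (estimated range 22000 nM to 110000 nM).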

Compound 3, half-maximal inhibitory concentration: 49100 nM
Compound 3: middle estimate off by 1.1-fold (0.05 log units), on the high side, within the range that was stated.
By their numbers in this assay, from the lowest: compounds 1, 3 and 2 (each within the scatter of the next, the first and the last beyond it).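

Within the data shown here, these are the first two single-place steps, and both stay within the scatter. In this assay, 3-(trifluoromethyl)phenyl in place of 4-methylphenyl on a nitrogen on an aromatic ring gives a 1.7-fold lower number from compound 2 to compound 3 (0.24 log units; within the scatter), so this exchange of one substituted phenyl for the other does not separate the two compounds. Hydrogen in place of methyl on an oxygen on an aromatic ring gives a 1.4-fold higher number from compound 1 to compound 3 (0.13 log units; within the scatter), so that position likewise shows no readable difference, and no supporting data bear on either step.

Open, on these data alone, is whether a group of another kind on that nitrogen, such as a carboxylic acid or an amine on the phenyl, would give a step beyond the scatter. The same holds for a longer chain, such as propyl, on that oxygen.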